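Enlarging the Basic Amine Tail of Compound 3

The source may report more compounds than this note shows. Statements on the series, on what has been measured and on what is new or still open speak of the compounds shown alone.

Three compounds sharing one core were measured in a functional assay on MCF7 cells (Homo sapiens) for antiproliferative activity, read by MTT assay, with a stated time of 72 h; on this read-out higher numbers stand for weaker inhibition and lower numbers for stronger inhibition. Compound 1 `COc1cc2ncnc(N3CCCc4ccccc43)c2cc1NC(=O)C=C(C)C` gives 6870 nM, compound 2 `COc1cc2ncnc(N3CCc4ccccc43)c2cc1NC(=O)/C=C/CN1CCN(C)CC1` gives 6430 nM, and compound 3 `COc1cc2ncnc(N3CCCc4ccccc43)c2cc1NC(=O)/C=C/CN(C)C` gives 1770 nM, the lowest of the three numbers; its nearest neighbour is compound 2 and its furthest is compound 1, both gaps standing beyond the scatter. Among the compounds with values here, the only step between compounds that differ in a single place, a 3.9-fold lower number from compound 1 to compound 3 (0.59 log units; beyond the scatter), put the 3-(dimethylamino)prop-1-en-1-yl group in place of the 2-methylprop-1-en-1-yl group on the carbonyl carbon.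

Compound 4 `COc1cc2ncnc(N3CCCc4ccccc43)c2cc1NC(=O)/C=C/CN1CCN(C)CC1` has not yet been measured. It differs from compound 3 by 4-methylpiperazin-1-yl in place of dimethylamino on a saturated chain carbon bound to a double-bonded chain carbon. Within the data shown here, no measured step covers this exact exchange. The closest point of comparison is compound 2, which carries the same 4-methylpiperazin-1-yl group but also differs from compound 3 in a second place, so its value only shows that a compound bearing this group sits some way above compound 3. The step of a 3.9-fold lower number from compound 1 to compound 3 (0.59 log units; beyond the scatter) concerns a different exchange and does not settle the direction. Compound 4 is therefore expected to give a somewhat higher number, a 1.8-fold higher number from compound 3 to compound 4 (0.26 log units; within the scatter), in this assay. The estimate for compound 4 in this assay is 3200 nM, with a range from 1100 nM to 9500 nM.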

Compound 4, half-maximal inhibitory concentration: 8560 nM
Compound 4: middle estimate off by 2.7-fold (0.43 log units), on the low side, within the range that was stated.
By their numbers in this assay, from the lowest: compound 3; then compounds 2, 1 and 4 (each within the scatter of the next).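

In this assay, the exchange of dimethylamino for 4-methylpiperazin-1-yl on a saturated chain carbon bound to a double-bonded chain carbon now has a measured size, a 4.8-fold higher number from compound 3 to compound 4 (0.68 log units; beyond the scatter), so this position is sensitive to which amine the chain carries. The lower number seen in a 3.9-fold lower number from compound 1 to compound 3 (0.59 log units; beyond the scatter) does not carry over to the larger amine: a 1.2-fold higher number from compound 1 to compound 4 (0.10 log units; within the scatter), and the tetrahydroquinoline exchange with this tail in place, a 1.3-fold higher number from compound 2 to compound 4 (0.12 log units; within the scatter), likewise shows no difference, so of the compounds shown only compound 3 stands apart from the others. Nothing reported with these numbers bears on why the two amines differ.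

As far as these compounds go, it remains open whether another amine on the same carbon, such as pyrrolidine, morpholine or diethylamino, would read like dimethylamino or like 4-methylpiperazin-1-yl. From the compounds shown here alone, it is also open whether dimethylamino would keep its lower number with 2,3-dihydro-1H-indol-1-yl in place of 1,2,3,4-tetrahydroquinolin-1-yl on the aromatic carbon.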